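Swapping the aryl group on a pyridine-like core

This account rests on a few compounds, and the source may have more. Where it says the series, first, only, none or still open, it means among the compounds named here.

Within the data shown here, compound 2 `COc1ccc(-c2cc(-c3cc4ccccc4o3)nc(OC)c2C#N)cc1` is one of two compounds measured in a functional assay on aorta (strain Wistar) for inhibition, with Thoracic aorta (Rattus norvegicus) as the target; a lower number here means a stronger inhibitor, a higher number a weaker inhibitor: compound 2 gives 262000 nM, and compound 1 `COc1nc(-c2cc3ccccc3o2)cc(-c2ccc(Br)cc2)c1C#N` gives 298000 nM. The two numbers sit within the scatter of each other, so neither can be called stronger; the step of a 1.1-fold lower number from compound 1 to compound 2 (0.06 log units; within the scatter) shows how little the methoxy-for-bromo exchange moved the result.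

Compound 3 `COc1nc(-c2cc3ccccc3o2)cc(-c2cccs2)c1C#N` carries a different change at the same site: thiophen-2-yl in place of 4-methoxyphenyl on an aromatic carbon, on an aromatic carbon of a six-membered aromatic ring with 1 nitrogen, ortho to a cyano group and opposite the ring nitrogen. Among the measured compounds shown here, the only measured step touched this same group and stayed within the scatter, which suggests the site tolerates variation, though a whole-ring exchange is a larger move than a single substituent swap.

Compound 3 is therefore expected to land near compound 2, with an estimated step of a 1.1-fold higher number from compound 2 to compound 3 (0.03 log units; within the scatter), giving an expected value of 280000 nM in this assay, within a range from 90000 nM to 900000 nM.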

Compound 3, half-maximal inhibitory concentration: 163000 nM
Beside the measured number, compound 3's estimate is 1.7-fold (0.23 log units) above it; the measured number falls inside the stated range.
By their numbers in this assay, from the lowest: compounds 3, 2 and 1 (each within the scatter of the next).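

Even replacing the whole ring leaves the result within the scatter: in this assay, exchanging the six-membered 4-methoxyphenyl for the five-membered thiophen-2-yl gives a 1.6-fold lower number from compound 2 to compound 3 (0.21 log units; within the scatter) as the step. Exchanging 4-bromophenyl for thiophen-2-yl gives a 1.8-fold lower number from compound 1 to compound 3 (0.26 log units; within the scatter) as the step, so the three aromatic groups at this position, opposite the ring nitrogen, cannot be told apart by this read-out. No measured information is available to explain these numbers.

Going by these compounds, whether a non-aromatic group here, such as an amine, a carboxylic acid or a longer chain, would move the number beyond the scatter stays open. So does the contribution of the 1-benzofuran-2-yl and methoxy groups, which stay the same in all three compounds.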